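This account rests on a few compounds, and the source may have more. Where it says the series, first, only, none or still open, it means among the compounds named here.

Measured so far:
- compound 1 `CC1(C)CC(=O)N(c2cnn3c2CN(C(=O)Nc2cc(F)c(F)c(F)c2)C(C2CC2)C3)C1`: 115000 nM
- compound 2 `O=C1CC(C(F)(F)F)CN1c1cnn2c1CN(C(=O)Nc1cc(F)c(F)c(F)c1)C(C1CC1)C2`: 115000 nM
- compound 3 `O=C1CC(c2ccc(F)cc2)CN1c1cnn2c1CN(C(=O)Nc1cc(F)c(F)c(F)c1)C(C1CC1)C2`: 32100 nM

In a toxicity assay on HepG2 2.2.15 cells (Homo sapiens) for cytotoxicity, read by CellTiter-Glo (on this read-out lower numbers stand for higher toxicity in this test and higher numbers for lower toxicity in this test), compound 3 has the lowest of the three numbers, at 32100 nM. Compound 4 `O=C1CC(c2nccs2)CN1c1cnn2c1CN(C(=O)Nc1cc(F)c(F)c(F)c1)C(C1CC1)C2` has not yet been measured. It differs from compound 3 by 1,3-thiazol-2-yl in place of 4-fluorophenyl on a saturated ring carbon.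

For the measured compounds named here, two measured steps bear on this change. The closer one introduced 4-fluorophenyl in place of trifluoromethyl, giving a 3.6-fold lower number from compound 2 to compound 3 (0.55 log units; beyond the scatter). The other gave no change at the digits printed from compound 1 to compound 2 (within the scatter). Going by the values given here, no compound with 1,3-thiazol-2-yl has been measured, so only a modest partial return towards compound 2 at 115000 nM is expected in this assay. The expected step, upward and smaller than the measured one, is a 1.7-fold higher number from compound 3 to compound 4 (0.23 log units; within the scatter). For compound 4 the estimated value is 55000 nM, with an expected range of 25000 nM to 115000 nM.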

Compound 4, half-maximal cytotoxic concentration: 115000 nM
The estimate for compound 4 lay 2.1-fold (0.32 log units) below the measured number; the range from low to high includes it.
By their numbers in this assay, from the lowest: compound 3; then compounds 1, 2 and 4 (each within the scatter of the next).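

In this assay 1,3-thiazol-2-yl in place of 4-fluorophenyl gives a 3.6-fold higher number from compound 3 to compound 4 (0.55 log units; beyond the scatter) and so an aromatic ring on this saturated ring carbon does not by itself carry the lower number. Against trifluoromethyl the same group gives no change at the digits printed from compound 2 to compound 4 (within the scatter) and against 4,4-dimethyl-2-oxopyrrolidin-1-yl it gives no change at the digits printed from compound 1 to compound 4 (within the scatter) and only the 4-fluorophenyl compound stands apart so far. No measurement at hand accounts for the gap between these two rings. Going by these compounds, whether an unsubstituted phenyl or a pyridine ring on this carbon would fall with compound 3 or with compound 4 stays open. On these data alone, an amine at the same place is equally open.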